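The source may hold more compounds than are shown below. What is called first, only, known or untested is meant among the compounds shown, and "the series" means these compounds.

Compound 1 `O=C1/C(=C\c2ccccc2)c2c(ncn2COCc2ccccc2)CCN1Cc1ccccc1`: 20000 nM
Compound 2 `Cc1cc(C)cc(CN2CCc3ncn(COCc4ccccc4)c3/C(=C/c3ccccc3)C2=O)c1`: 6230 nM
Compound 3 `O=C1/C(=C\c2ccccc2)c2c(ncn2COCc2ccccc2)CCN1Cc1ccc(Cl)cc1`: 10500 nM

In a functional assay on HCT-116 cells (Homo sapiens) for inhibition, read by MTT assay, with a stated time of 72 h (on this read-out lower numbers stand for stronger inhibition and higher numbers for weaker inhibition), compound 1 gives 20000 nM, which places it at the upper end of the numbers shown, together with compound 3. Compound 4 `O=C1/C(=C\c2ccncc2)c2c(ncn2COCc2ccccc2)CCN1Cc1ccccc1`, not yet measured, differs from compound 1 as follows: pyridin-4-yl in place of phenyl on a double-bonded chain carbon bound to a double-bonded ring carbon. This puts pyridin-4-yl in place of phenyl on a double-bonded chain carbon bound to a double-bonded ring carbon. Going by the values given here, no measured step lies at that place. The nearest guides are changes elsewhere: a 3.2-fold lower number from compound 1 to compound 2 (0.51 log units; beyond the scatter), and a 1.9-fold lower number from compound 1 to compound 3 (0.28 log units; within the scatter). As far as these compounds go, both are small, so no step beyond the scatter is expected, and the direction remains open. The expected step is a 1.4-fold lower number from compound 1 to compound 4 (0.15 log units; within the scatter). For compound 4 the estimated value is 14000 nM, with an expected range of 5000 nM to 35000 nM.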

Compound 4, half-maximal inhibitory concentration: 67100 nM
The estimate for compound 4 lay 4.8-fold (0.68 log units) below the measured number, and the stated range ends below it.
By their numbers in this assay, from the lowest: compounds 2, 3 and 1 (each within the scatter of the next, the first and the last beyond it); then compound 4.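

In this assay, the place on a double-bonded chain carbon bound to a double-bonded ring carbon proves sensitive to change: pyridin-4-yl in place of phenyl gives a 3.4-fold higher number from compound 1 to compound 4 (0.53 log units; beyond the scatter) as a step beyond the scatter. Of the steps from compound 1, this one alone gives a higher number, and it runs opposite to a 3.2-fold lower number from compound 1 to compound 2 (0.51 log units; beyond the scatter) at the other place. The entering group brings one hetero atom, counted as a hydrogen-bond acceptor, but no evidence at hand bears on the cause of the step.

As far as these compounds go, whether pyridin-3-yl or an amine on the phenyl at this place would give a similar step stays open. So does whether the step would hold with the 3,5-dimethylphenyl of compound 2 or the 4-chlorophenyl of compound 3.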